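The compounds below may be only part of what the source reports. "The series", "measured", "known", "first", "only" and "open" are said of these compounds alone.

The measured compounds, each with its own value:

Compound 1, `CC1CCN(C2CCN(S(=O)(=O)c3cccc(-c4ccccc4F)c3)CC2)CC1`, gives a limit of the assay rather than a number, > 5000 nM.
Compound 2, `Cc1cc(C)cc(-c2cccc(S(=O)(=O)N3CCC(N4CCC(C)CC4)CC3)c2)c1`, likewise gives only a limit, > 5000 nM.
Compound 3, `CC1CCN(C2CCN(S(=O)(=O)c3cccc(-c4ccc5ccccc5c4)c3)CC2)CC1`, also gives only a limit, > 5000 nM.

These values come from an ADME assay on HCT-116 cells (Homo sapiens) for cytotoxicity, read by CellTiter-Glo, with a stated time of 72 h; on this read-out higher numbers stand for weaker inhibition and lower numbers for stronger inhibition. Compound 3 therefore stands at the limit of this assay, and the same holds for every value shown, since (the limit of > 5000 nM in this assay, at which 3 of the 3 values shown sit). For the measured compounds named here, no compound can be ranked against another on these numbers.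

The next compound, compound 4, is `CC1CCN(C2CCN(S(=O)(=O)c3cccc(-c4ccccc4)c3)CC2)CC1`. Relative to compound 3 the change is phenyl in place of naphthalen-2-yl on an aromatic carbon. The measured steps that bear on this change, a step that the two limits leave unreadable from compound 1 to compound 3 and a step that the two limits leave unreadable from compound 2 to compound 3, are both unreadable, because each end sits at the limit; the step that the two limits leave unreadable from compound 1 to compound 2 is unreadable for the same reason. Going by the values given here, no measured step reveals how changing the aromatic group alters cytotoxicity here, so nothing suggests compound 4 will leave the limit. The step expected is a step that the limit leaves unreadable from compound 3 to compound 4, meaning no readable change. Compound 4 is thus expected to give about 8000 nM, within 4000 nM to 20000 nM, most likely reported again as a limit.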

Compound 4, half-maximal inhibitory concentration: > 5000 nM
Compound 4: only a limit was reported; the forecaster's own chance of this, stated with the estimate: 85%; the middle value is on the limit's open side.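

Compound 4 also gives only a limit, > 5000 nM. Its steps from compound 1, compound 2 and compound 3 cannot be read, because all of these compounds sit at the same limit: the limit of > 5000 nM in this assay, at which 4 of the 4 values shown sit. The compounds shown leave open whether changing the aromatic group alters the result in this assay at all.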